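A few compounds are considered here, and "the series" means these few. Any claim that something is new, unique, unknown or untested is made for them only; others in the source may bear on it.

Of the compounds shown here, three have been measured in an assay for inhibition of Alpha amylase (Homo sapiens), with a stated time of 10 min; on this read-out higher numbers stand for weaker inhibition and lower numbers for stronger inhibition. Compound 1 `COc1ccc(-c2nc3cc(F)ccc3[nH]2)c(F)c1` gives 1590 nM. Compound 2 `COc1cc(-c2nc3cc(F)ccc3[nH]2)ccc1OC(C)=O` gives 1680 nM. Compound 3 `COc1cc(-c2nc3cc(Cl)ccc3[nH]2)cc(I)c1O` gives 1610 nM. For the measured compounds named here, the three numbers sit close together: the gap from compound 3 to compound 1 and the gap from compound 3 to compound 2 both fall within the usual scatter of this assay, so no compound can be set apart from the others on these data.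

Compound 4 `COc1cc(-c2nc3cc(Cl)ccc3[nH]2)cc(OC)c1O` has not yet been measured. It differs from compound 3 in one place: methoxy in place of iodo on an aromatic carbon. Going by the values given here, no pair of measured compounds shows the effect of such a change, so there is no reference step to lean on. The three measured compounds, which differ from one another in several places at once, all land close to the same value, and this gives no reason to expect a large move in either direction. Compound 4 is therefore expected to give about 1700 nM in this assay, within a range of 800 nM to 3600 nM, and the expected step from compound 3 to compound 4 is a 1.1-fold higher number from compound 3 to compound 4 (0.02 log units; within the scatter), not beyond the scatter.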

Compound 4, half-maximal inhibitory concentration: 2520 nM
Compound 4: middle estimate off by 1.5-fold (0.17 log units), on the low side; low and high end bracket the measured number.
By their numbers in this assay, from the lowest: compounds 1, 3, 2 and 4 (each within the scatter of the next).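

Methoxy in place of iodo, on the aromatic carbon ortho to a hydroxy group, gives a 1.6-fold higher number from compound 3 to compound 4 (0.19 log units; within the scatter) in this assay, the first direct reading of any single change in this series. At this position, then, the exchange of iodo for methoxy, which adds one heavy atom and one hydrogen-bond acceptor, does not shift the number beyond the scatter. Nothing measured here accounts for the size of this step.

The compounds shown leave open whether an amine, a carboxylic acid or a longer alkoxy chain at this position would read differently from iodo and methoxy. For the compounds shown here, they also leave open whether the same exchange would give a similar step on a core other than the one shared by compound 3 and compound 4.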